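Aryloxy ketone series: nitro to trifluoro exchange

A few compounds are considered here, and "the series" means these few. Any claim that something is new, unique, unknown or untested is made for them only; others in the source may bear on it.

Compound 1 `CC(C)[C@H](NC(=O)COc1cccc2ccccc12)C(=O)N[C@@H](CC(=O)O)C(=O)COc1ccc(-c2ccccc2)cc1` carries 4-phenylphenyl on the oxygen on a saturated carbon; in a functional assay on Jurkat cells (Homo sapiens) (a higher number here means a weaker inhibitor, a lower number a stronger inhibitor), compound 1 gives 87900 nM. Compound 2 `CC(C)[C@H](NC(=O)COc1cccc2ccccc12)C(=O)N[C@@H](CC(=O)O)C(=O)COc1ccc(C#N)cc1` bears cyano in place of phenyl on an aromatic carbon. In this assay compound 2 reaches only the limit > 100000 nM. Compound 3 `CC(C)[C@H](NC(=O)COc1cccc2ccccc12)C(=O)N[C@@H](CC(=O)O)C(=O)COc1ccccc1[N+](=O)[O-]` has 2-nitrophenyl on the oxygen on a saturated carbon. In this assay compound 3 likewise stands at the limit > 100000 nM, so only a limit is known for it. The step of an at least 1.1-fold higher number from compound 1 to compound 3 (0.05 log units; that floor lies within the scatter) is readable only as a floor, and a step that the two limits leave unreadable from compound 2 to compound 3 cannot be sized at all; both rest on (the limit of > 100000 nM in this assay, at which 2 of the 3 values shown sit). Compound 4 `CC(C)[C@H](NC(=O)COc1cccc2ccccc12)C(=O)N[C@@H](CC(=O)O)C(=O)COc1c(F)ccc(F)c1F` differs from compound 3 in one place: 2,3,6-trifluorophenyl in place of 2-nitrophenyl on an oxygen on a saturated carbon. Within the data shown here, no measured step exchanges one substituted phenyl for another inside the readable range, so the data give no direction for this change. Compound 4 is expected to remain at or near the limit, with a number no higher from compound 3 to compound 4 (the limit leaves the size open) as the estimated step. For compound 4 in this assay the estimate is 100000 nM, spanning 30000 nM to 300000 nM.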

Compound 4, half-maximal inhibitory concentration: 1200 nM
Beside the measured number, compound 4's estimate is 83-fold (1.92 log units) above it; measured number outside the range, below it.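

In this assay, the group on the oxygen on a saturated carbon proves able to bring the series off its limit, with an at least 83-fold lower number from compound 3 to compound 4 (1.92 log units; beyond the scatter) and an at least 83-fold lower number from compound 2 to compound 4 (1.92 log units; beyond the scatter). Among these compounds, the change also holds against the only earlier compound with a true number, with a 73-fold lower number from compound 1 to compound 4 (1.86 log units; beyond the scatter), so the drop does not rest on a limit alone. The first two steps are floors, and their full size stays open: the limit of > 100000 nM in this assay, at which 2 of the 4 values shown sit.

The compounds shown leave open whether the drop needs all three fluorine atoms, or whether a single fluorophenyl, a chlorophenyl or a pentafluorophenyl group on the same oxygen would give it too. Also open, from the compounds shown here alone, is whether the 2,3,6-trifluorophenyl group keeps this effect when the carboxylic acid of the shared core gives way to a primary amide.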